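Swapping One Group on a Cell-Active Amide

This account rests on a few compounds, and the source may have more. Where it says the series, first, only, none or still open, it means among the compounds named here.

In a functional assay on MIA PaCa-2 cells (Homo sapiens) for inhibition, read by MTT assay (on this read-out lower numbers stand for stronger inhibition and higher numbers for weaker inhibition), compound 1 (`CCC(CO)Nc1ncc2cc(C(=O)N(C)C)n(C3CCCC3)c2n1`) gives 31000 nM and compound 2 (`COc1ccccc1NC(=O)c1cc2cnc(Nc3ccc(N4CCNCC4)cn3)nc2n1C1CCCC1`) gives 1830 nM as the lower number of the two, a gap beyond the usual scatter. Compound 3 (`O=C(Nc1ccccc1C(F)(F)F)c1cc2cnc(Nc3ccc(N4CCNCC4)cn3)nc2n1C1CCCC1`) has trifluoromethyl in place of methoxy on an aromatic carbon, ortho to a large group (trifluoromethyl in place of methoxy on an aromatic carbon). Among the measured compounds shown here, no measured pair shows this swap, so in this assay no change beyond the scatter is expected, with an estimated 1.1-fold higher number from compound 2 to compound 3 (0.04 log units; within the scatter) as the step. Compound 3 is expected at an estimated 2000 nM with a range from 800 nM to 5000 nM on this read-out.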

Compound 3, half-maximal inhibitory concentration: 3160 nM
For compound 3 the middle estimate is 1.6-fold (0.20 log units) below the measured one; the measured number falls inside the stated range.
By their numbers in this assay, from the lowest: compounds 2 and 3 (each within the scatter of the next); then compound 1.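

In this assay, changing 2-methoxyphenyl to 2-(trifluoromethyl)phenyl gives a 1.7-fold higher number from compound 2 to compound 3 (0.24 log units; within the scatter), so this read-out does not separate the two groups at this position. The pair also shows that the hydrogen-bond acceptor counted on methoxy, absent from trifluoromethyl, can go with no change beyond the scatter. Nothing available explains why the two compounds read alike. Still open, on these data alone, is how this aromatic carbon responds to a group of another kind, such as an amine or a carboxylic acid. A longer chain, such as ethoxy, is equally untested by these compounds.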